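Swapping the Ring Nitrogen Substituent: From Compound 2 to Compound 3

A few compounds are considered here, and "the series" means these few. Any claim that something is new, unique, unknown or untested is made for them only; others in the source may bear on it.

Compound 1, `CCOC(=O)N1CCN(C(=S)Nc2ccnc3cc(Cl)ccc23)CC1`: in a functional assay on HeLa cells (Homo sapiens) for cytotoxicity, read by MTT assay, with a stated time of 7 h (a higher number here means a weaker inhibitor, a lower number a stronger inhibitor), compound 1 gives 40100 nM.
Compound 2, `S=C(Nc1ccnc2cc(Cl)ccc12)N1CCN(CC2CCCCC2)CC1`: in this assay compound 2 gives only a limit, > 50000 nM.

For the measured compounds named here, the one measured step, an at least 1.2-fold higher number from compound 1 to compound 2 (0.09 log units; that floor lies within the scatter), cyclohexylmethyl in place of ethoxycarbonyl on an amine nitrogen in a ring, rests on the limit of > 50000 nM in this assay, at which 1 of the 2 values shown sits, and lies within the scatter. Compound 2 stands at that limit, with no number of its own. Compound 3, `S=C(Nc1ccnc2cc(Cl)ccc12)N1CCN(c2ccccc2)CC1`, differs from compound 2 by phenyl in place of cyclohexylmethyl on an amine nitrogen in a ring. Going by the values given here, only the step from compound 1 to compound 2 touches this amine nitrogen in a ring, and it was small; nothing measured distinguishes a cyclohexylmethyl from a phenyl at this place. The step of a number no higher from compound 2 to compound 3 (the limit leaves the size open) is expected to stay within the scatter. Compound 3 is estimated at 50000 nM, in the range 20000 nM to 150000 nM, and most likely again only a limit.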

Compound 3, half-maximal inhibitory concentration: 43600 nM
Estimate against measurement, compound 3: 1.1-fold (0.06 log units) above; the range from low to high includes it.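

Phenyl in place of ethoxycarbonyl gives a 1.1-fold higher number from compound 1 to compound 3 (0.04 log units; within the scatter), so in this assay these two groups on the amine nitrogen in a ring cannot be told apart, and this position now holds two measured numbers rather than one. Phenyl in place of cyclohexylmethyl gives an at least 1.1-fold lower number from compound 2 to compound 3 (0.05 log units; that floor lies within the scatter). The size of that step stays open because compound 2 has only a limit, not a number of its own: the limit of > 50000 nM in this assay, at which 1 of the 3 values shown sits.

The compounds shown leave open whether an amine, a carboxylic acid or a longer chain on this nitrogen would move the number in this assay beyond the scatter. They also leave open whether a change on the shared core, away from this nitrogen, would do so.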